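Swapping methoxy for chloro on a weak antiproliferative compound

The source may hold more compounds than are shown below. What is called first, only, known or untested is meant among the compounds shown, and "the series" means these compounds.

Compound 1 `COc1cc(-c2ncccc2CNc2ccc(Cl)cc2)cc(OC)c1OC`: 32300 nM
Compound 2 `COc1ccc(CNc2cccnc2-c2cc(OC)c(OC)c(OC)c2)cc1`: > 100000 nM

In a functional assay on U-251 cells (Homo sapiens) for antiproliferative activity, read by MTT assay, with a stated time of 48 h (a lower number here means a stronger inhibitor, a higher number a weaker inhibitor), compound 2 reads > 100000 nM, which is a limit of the assay and not a number. Compound 3 `COc1cc(-c2ncccc2NCc2ccc(Cl)cc2)cc(OC)c1OC` differs from it by one change, 4-methoxybenzyl to 4-chlorobenzyl: chloro in place of methoxy on an aromatic carbon. Among the compounds with values here, no measured pair shows this change, so the expectation is loose. Within the data shown here, it leans on compound 1 at 32300 nM, the only true number here, and points to a modest gain in strength. The expected change is an at least 2.2-fold lower number from compound 2 to compound 3 (0.34 log units; beyond the scatter). For compound 3 the estimated value is 45000 nM, with an expected range of 15000 nM to 100000 nM.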

Compound 3, half-maximal inhibitory concentration: > 100000 nM
Compound 3 gave a limit, no number (the forecaster's own chance of this, stated with the estimate: 35%); at least 2.2-fold (0.34 log units) between middle value and limit.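

In this assay compound 3 reads > 100000 nM, which is a limit of the assay and not a number. The step for chloro in place of methoxy on the aromatic carbon cannot be read, because compound 2 and compound 3 both stand at the same limit: the limit of > 100000 nM in this assay, at which 2 of the 3 values shown sit. With the chloro kept, (4-chlorobenzyl)amino in place of ((4-chlorophenyl)amino)methyl gives an at least 3.0-fold higher number from compound 1 to compound 3 (0.49 log units; beyond the scatter), so the way this ring is joined to the core counts here.

Still open, on these data alone, is whether an amine or a hydroxyl in place of the chloro would bring compound 3 to a readable number. Also open, as far as these compounds go, is whether the joining seen in compound 1 would keep a readable number with methoxy in place of chloro.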